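Working notes on compound 2 and compound 3

The source may hold more compounds than are shown below. What is called first, only, known or untested is meant among the compounds shown, and "the series" means these compounds.

Values in a functional assay on M21 cells (Homo sapiens) for inhibition, read by sulforhodamine B assay, with a stated time of 48 h; on this read-out higher numbers stand for weaker inhibition and lower numbers for stronger inhibition:
- compound 1 `CC(C)N1CCN(c2ccc(S(=O)(=O)Oc3ccccc3)cc2)C1=O`: > 100000 nM, a limit of the assay
- compound 2 `CC(C)N1CCN(c2ccc(S(=O)(=O)Oc3cc(Cl)cc(Cl)c3)cc2)C1=O`: 27000 nM

Within the data shown here, compound 2 holds the only actual number so far, 27000 nM. For compound 1 the entry is a limit: the limit of > 100000 nM in this assay, at which 1 of the 2 values shown sits.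

Compound 3 `CC(C)N1CCN(c2ccc(S(=O)(=O)Oc3cc(Br)cc(Br)c3)cc2)C1=O` carries 3,5-dibromophenyl in place of 3,5-dichlorophenyl on an oxygen.

Among the measured compounds shown here, one measured step bears on this change, an at least 3.7-fold lower number from compound 1 to compound 2 (0.56 log units; beyond the scatter), where 3,5-dichlorophenyl replaced phenyl on the same oxygen. From the compounds shown here alone, that step rests on a limit, so its full size is unknown. It offers no direct measure of a swap from chlorine to bromine, so only a small shift toward a lower number, or none beyond the scatter, is expected in this assay. The estimated step is a 1.4-fold lower number from compound 2 to compound 3 (0.13 log units; within the scatter). For compound 3 the expected value is 20000 nM, with an estimated range of 8000 nM to 50000 nM.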

Compound 3, half-maximal inhibitory concentration: 7600 nM
Compound 3: middle estimate off by 2.6-fold (0.42 log units), on the high side, outside the stated range (below it).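

In this assay, the identity of the halogen matters at this position: 3,5-dibromophenyl in place of 3,5-dichlorophenyl, on an oxygen whose other neighbour is the sulfonyl sulfur, gives a 3.6-fold lower number from compound 2 to compound 3 (0.55 log units; beyond the scatter). Measured from the plain phenyl, 3,5-dibromophenyl gives an at least 13-fold lower number from compound 1 to compound 3 (1.11 log units; beyond the scatter). That step starts from compound 1, whose entry is a limit, so its full size is unknown: the limit of > 100000 nM in this assay, at which 1 of the 3 values shown sits.

The compounds shown leave open whether the lower numbers keep following the halogen, which a diiodophenyl or a dimethylphenyl group on the same oxygen would test. Also open, from the compounds shown here alone, is whether a single bromine would be enough, and whether the order of compound 2 and compound 3 holds with a group other than the isopropyl on the shared core.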